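Capping a Hydroxy Group: From Compound 1 to Compound 3

This account rests on a few compounds, and the source may have more. Where it says the series, first, only, none or still open, it means among the compounds named here.

Compound 1 `C=C1C(=O)O[C@H](C2=C(C)[C@@H](O)CC2=O)[C@@H]1CCC(C)=O` carries a free hydroxy group on its shared core. In a functional assay on HaCaT cells (Homo sapiens) for cytotoxicity, read by ELISA and LDH release, with a stated time of 6 h, tested at 100 ug/mL (a lower number here means a stronger effect, a higher number a weaker effect of the compound at the concentration tested), compound 1 is recorded as "not determined" (no result reported), so it has no single number to stand on. Its close relative compound 2 `C=C1C(=O)O[C@H](C2=C(C)C(O)CC2=O)[C@@H]1CCC(C)=O` differs from compound 1 only in the fact that one of compounds 1 and 2 is drawn with a defined configuration and the other without, at the place where they differ. In this assay compound 2 gives a value of 0%, which at the tested concentration means no measurable effect on the cells. Compound 3 `C=C1C(=O)O[C@H](C2=C(C)[C@@H](OC)CC2=O)[C@@H]1CCC(C)=O` is the compound that follows, and it differs from compound 1 by methyl in place of hydrogen on an oxygen on a saturated carbon. For the measured compounds named here, no measured pair shows what such a change does in this assay, so the size of the step cannot be read from the data; with compound 2 at 0%, a step of no more than the usual scatter in either direction is the simplest expectation. Compound 3 is therefore expected to give about 5% in this assay, within an estimated range of 0% to 25%.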

Compound 3, a percentage reported as activity, at one concentration (the size of the read-out at that concentration, not a potency): 0%
For compound 3 the middle estimate is 5 percentage points above the measured one; low and high end bracket the measured number.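

In this assay, for the compounds shown here, compound 3 gives 0%, while compound 1 is recorded as "not determined" (no result reported), so no step between the two can be read. The compounds shown leave open what hydroxy to methoxy does in this assay, and whether the result for compound 2 also holds for compound 1, given how those two differ: the fact that one of compounds 1 and 2 is drawn with a defined configuration and the other without, at the place where they differ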